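A few compounds are considered here, and "the series" means these few. Any claim that something is new, unique, unknown or untested is made for them only; others in the source may bear on it.

The compounds here share one core and differ in the group attached to the carbon that carries a double bond to nitrogen. Compound 1 `COc1cc2c(Oc3ccc(NC(=O)N/N=C/c4ccc(C(F)(F)F)cc4)cc3F)ccnc2cc1OCCCN1CCCCC1` gives 660 nM in a functional assay on HT-29 cells (Homo sapiens) for cytotoxicity, read by MTT assay, with a stated time of 72 h; a lower number here means a stronger inhibitor, a higher number a weaker inhibitor. Compound 2 `C=CCc1cccc(/C=N/NC(=O)Nc2ccc(Oc3ccnc4cc(OCCCN5CCCCC5)c(OC)cc34)c(F)c2)c1OC` gives 460 nM in this assay. Compound 3 `COc1cc2c(Oc3ccc(NC(=O)N/N=C/c4ccncc4)cc3F)ccnc2cc1OCCCN1CCCCC1` gives 940 nM in this assay. Among these three numbers compound 3 stands highest, though its gap to compound 1 is within the scatter, a 1.4-fold higher number from compound 1 to compound 3 (0.15 log units; within the scatter), and only its gap to compound 2 lies beyond it, a 2.0-fold higher number from compound 2 to compound 3 (0.31 log units; beyond the scatter). The remaining step was similarly small, a 1.4-fold lower number from compound 1 to compound 2 (0.16 log units; within the scatter).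

Compound 4 `COc1cc2c(Oc3ccc(NC(=S)N/N=C/c4ccccc4)cc3F)ccnc2cc1OCCCN1CCCCC1` differs from compound 3 in one place: a group of 11 heavy atoms (8 carbon, 2 nitrogen, 1 sulfur; one six-membered aromatic ring of carbon only) in place of a group of 11 heavy atoms (7 carbon, 3 nitrogen, 1 oxygen; one six-membered aromatic ring with 1 hetero atom), on a nitrogen on an aromatic ring. Part of this change, the swap of one aromatic ring for another, resembles the measured steps, all of which were small or modest. The other part, the exchange of an oxygen for a sulfur within the replaced group, has no measured counterpart among these compounds, so nothing here tells its direction. Only a small step is therefore expected, a 1.3-fold lower number from compound 3 to compound 4 (0.13 log units; within the scatter), with the bare aromatic ring of carbon unlikely to move the number far from the modest span already seen. In this assay compound 4 is estimated at 700 nM, with a range from 250 nM to 2000 nM.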

Compound 4, half-maximal inhibitory concentration: 210 nM
For compound 4 the middle estimate is 3.3-fold (0.52 log units) above the measured one; the whole stated range lies above it.
By their numbers in this assay, from the lowest: compound 4; then compounds 2, 1 and 3 (each within the scatter of the next, the first and the last beyond it).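

In this assay, among the compounds shown here, the change brings a 4.5-fold lower number from compound 3 to compound 4 (0.65 log units; beyond the scatter), which is larger than any step among the earlier compounds, where the biggest was a 2.0-fold higher number from compound 2 to compound 3 (0.31 log units; beyond the scatter). Those earlier steps exchanged only the group on the carbon with a double bond to nitrogen, whereas this one also puts a sulfur in place of the oxygen, so the result shows that a change reaching this far into the group on the aromatic nitrogen can move the number further than those exchanges did. No measurement shown here explains the size or the direction of this step.

Compound 4 differs from compound 3 in both the sulfur and the ring of carbon only, so this single step cannot say how much of the drop belongs to each; that would take the oxygen version carrying the ring of carbon only, or the sulfur version carrying the pyridin-4-yl ring. Also open, going by these compounds, is how the number would respond to a different atom in that same spot, such as an imine nitrogen in place of the sulfur.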